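A third methoxy group for compound 2

A few compounds are considered here, and "the series" means these few. Any claim that something is new, unique, unknown or untested is made for them only; others in the source may bear on it.

In an ADME assay on cells (Lymphocyte, Homo sapiens) for cytotoxicity, read by MTT assay, with a stated time of 48 h (on this read-out lower numbers stand for stronger inhibition and higher numbers for weaker inhibition), compound 1 (`COC(=O)/C(=C\c1ccc(OC(=O)c2ccccc2)cc1)Sc1ccnc2cc(Cl)ccc12`) gives > 100000 nM, which is a limit of the assay and not a number. Among the measured compounds shown here, compound 2 (`COC(=O)/C(=C\c1ccc(OC(=O)c2ccc(OC)cc2OC)cc1)Sc1ccnc2cc(Cl)ccc12`) gives 41600 nM, the only actual number so far. For the measured compounds named here, the one measured step, an at least 2.4-fold lower number from compound 1 to compound 2 (0.38 log units; beyond the scatter), came with 2,4-dimethoxyphenyl in place of phenyl on a carbonyl carbon, and its size is only a bound. Compound 3 (`COC(=O)/C(=C\c1ccc(OC(=O)c2ccc(OC)c(OC)c2OC)cc1)Sc1ccnc2cc(Cl)ccc12`) has methoxy in place of hydrogen on an aromatic carbon, ortho to two methoxy groups: methoxy in place of hydrogen on an aromatic carbon. A single added methoxy is expected to move the number less, in the same direction. The expected change is a 1.3-fold lower number from compound 2 to compound 3 (0.10 log units; within the scatter), possibly within the scatter. For compound 3 the estimate is 33000 nM, with an expected range of 14000 nM to 80000 nM.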

Compound 3, half-maximal inhibitory concentration: 22400 nM
Compound 3: the middle estimate sits 1.5-fold (0.17 log units) above what was measured, and the stated range covers the measured number.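

Set ortho to two methoxy groups, the third methoxy gives a 1.9-fold lower number from compound 2 to compound 3 (0.27 log units; within the scatter), so in this assay this position shows no change that stands clear of repeated measurement. The whole change from phenyl to 2,3,4-trimethoxyphenyl gives an at least 4.4-fold lower number from compound 1 to compound 3 (0.64 log units; beyond the scatter). Compound 1 stands at a limit and not at a number, so the size of that step is only a bound: the limit of > 100000 nM in this assay, at which 1 of the 3 values shown sits.

The compounds shown leave open whether an amine or a carboxylic acid at this position would move the number beyond the scatter. They also leave open what a single methoxy group on the phenyl would give alone.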